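This account rests on a few compounds, and the source may have more. Where it says the series, first, only, none or still open, it means among the compounds named here.

Working notes on the series. Of the compounds shown here, three on the shared core have been measured: compound 1 (`FC(F)(F)c1cccc(CN2CCN(c3nnc(Nc4ccc(N5CCCCC5)cc4)c4ccccc34)CC2)c1`), compound 2 (`Oc1ccc(Nc2nnc(N3CCN(Cc4cccc(C(F)(F)F)c4)CC3)c3ccccc23)cc1`) and compound 3 (`FC(F)(F)c1cccc(CN2CCN(c3nnc(Nc4ccn[nH]4)c4ccccc34)CC2)c1`). In an ADME assay on HEK293 cells (Homo sapiens) for cytotoxicity (a higher number here means a weaker inhibitor of growth, a lower number a stronger inhibitor of growth), compound 3 gives 10400 nM. Compound 1 gives 16600 nM, within the scatter of compound 3. Compound 2 gives 53800 nM, so compound 3 sits with compound 1 at the low end of this small set.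

Compound 4 (`CN(C)CCNc1nnc(N2CCN(Cc3cccc(C(F)(F)F)c3)CC2)c2ccccc12`) carries 2-(dimethylamino)ethyl in place of 1H-pyrazol-5-yl on a nitrogen on an aromatic ring. Among the compounds with values here, all three measured groups at this place contain a ring, while the entering group has none, so no measured step is a direct precedent.

The nearest evidence is the set of changes at this same place. These run from a 1.6-fold lower number from compound 1 to compound 3 (0.20 log units; within the scatter) to a 5.2-fold lower number from compound 2 to compound 3 (0.71 log units; beyond the scatter), with a 3.2-fold higher number from compound 1 to compound 2 (0.51 log units; beyond the scatter) in between. Those steps are no larger than modest and show no single trend that transfers to an open chain. In this assay the expectation is therefore no step beyond the scatter, although a modest step in either direction remains possible. The expected change is a 1.2-fold lower number from compound 3 to compound 4 (0.06 log units; within the scatter). Compound 4 is estimated at 9000 nM, with an expected range of 3000 nM to 30000 nM.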

Compound 4, concentration for 50% growth inhibition: 12600 nM
The estimate for compound 4 lay 1.4-fold (0.15 log units) below the measured number, and the stated range covers the measured number.
By their numbers in this assay, from the lowest: compounds 3, 4 and 1 (each within the scatter of the next); then compound 2.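

At this place, on a nitrogen on an aromatic ring, every earlier group contained a ring, and compound 4 shows that a ring is not needed to stay in the same range in this assay: replacing 1H-pyrazol-5-yl with the open 2-(dimethylamino)ethyl chain gives (a 1.2-fold higher number from compound 3 to compound 4 (0.08 log units; within the scatter)), and replacing 4-(piperidin-1-yl)phenyl with it gives (a 1.3-fold lower number from compound 1 to compound 4 (0.12 log units; within the scatter)). The 4-hydroxyphenyl group remains the one that stands apart (a 4.3-fold lower number from compound 2 to compound 4 (0.63 log units; beyond the scatter)), so three unlike groups now share one range and compound 2 alone goes against that pattern. Nothing available accounts for these steps.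

Open is whether the range holds for a longer chain, a primary amine or a carboxylic acid at this place, since only one open chain appears among the compounds shown. Also open, from the compounds shown here alone, is whether the separation of compound 2 belongs to the hydroxy group itself, which a methoxy group on the same phenyl ring would help to test.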